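Phenyl for Chloro on the Benzyloxy Ring of Compound 2

The source may hold more compounds than are shown below. What is called first, only, known or untested is meant among the compounds shown, and "the series" means these compounds.

Measured compounds in an assay on CHO cells for binding affinity to metabotropic glutamate receptor 2 (Rattus norvegicus); on this read-out higher numbers stand for weaker inhibition and lower numbers for stronger inhibition:
compound 1 `N[C@]1(C(=O)O)[C@H]2[C@@H](C[C@H]1OCc1ccccc1)[C@]2(F)C(=O)O`: 7.14 nM
compound 2 `N[C@]1(C(=O)O)[C@H]2[C@@H](C[C@H]1OCc1ccccc1Cl)[C@]2(F)C(=O)O`: 4.99 nM

In this assay, among the measured compounds shown here, compound 2 holds the lower of the two numbers, but its only neighbour is compound 1, and the step of a 1.4-fold lower number from compound 1 to compound 2 (0.16 log units; within the scatter) lies within the scatter, so the two values cannot be ranked against each other. Compound 3 `N[C@]1(C(=O)O)[C@H]2[C@@H](C[C@H]1OCc1ccccc1-c1ccccc1)[C@]2(F)C(=O)O` is the next member: phenyl in place of chloro on an aromatic carbon, on an aromatic carbon of a six-membered aromatic ring of carbon only, ortho to a large group. For the measured compounds named here, the single measured step that touches this part of the molecule, a 1.4-fold lower number from compound 1 to compound 2 (0.16 log units; within the scatter), is small. Going by the values given here, nothing measured so far shows what a phenyl ring at this carbon does, so the expectation for compound 3 rests on that one small step and on a wide range. Compound 3 is expected to give about 6 nM, within roughly 2 nM to 20 nM. The expected step is therefore a 1.2-fold higher number from compound 2 to compound 3 (0.08 log units; within the scatter), that is, no change beyond the scatter.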

Compound 3, inhibition constant: 4.07 nM
Beside the measured number, compound 3's estimate is 1.5-fold (0.17 log units) above it; the measured number falls inside the stated range.
By their numbers in this assay, from the lowest: compounds 3, 2 and 1 (each within the scatter of the next).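

In this assay, the carbon that carries chloro in compound 2 also takes a whole six-membered aromatic ring: the change to phenyl gives a 1.2-fold lower number from compound 2 to compound 3 (0.09 log units; within the scatter), and phenyl in place of hydrogen gives a 1.8-fold lower number from compound 1 to compound 3 (0.24 log units; within the scatter). Both steps lie within the scatter, so hydrogen, chloro and phenyl at this carbon cannot be told apart on this read-out, even with a group as large as phenyl entering. No supporting evidence bears on this result.

The three compounds leave open whether any group at this carbon moves the number beyond the scatter, since all of them carry only hydrogen, chloro or phenyl there. An amine, a carboxylic acid or a longer chain at this carbon could answer that, and so could phenyl on another carbon of the same ring.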